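Replacing an ether side chain with a pentynyl chain

The source may report more compounds than this note shows. Statements on the series, on what has been measured and on what is new or still open speak of the compounds shown alone.

Compound 1 `Nc1ccc2cccc(OC3CCCCC3)c2n1` and compound 2 `CC(C)OCCOc1cccc2ccc(N)nc12` share one core and differ only in the group on the ether oxygen. In an assay on cells with melanin-concentrating hormone receptor 1 (Homo sapiens) as the target, read by radioligand binding (a higher number here means a weaker inhibitor, a lower number a stronger inhibitor), compound 1 gives 361 nM. For compound 2 this assay reports only a limit, > 2000 nM, so its true value is not a number; it sits at the limit of > 2000 nM in this assay, at which 1 of the 2 values shown sits. Compound 2 therefore stands at the weaker end of what is known here.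

Compound 3 `CCC#CCOc1cccc2ccc(N)nc12` is not yet measured and differs from compound 2 by but-1-yn-1-yl in place of isopropoxymethyl on a saturated chain carbon bound to an oxygen on an aromatic ring. Among the measured compounds shown here, the only measured step touching this side chain is an at least 5.5-fold higher number from compound 1 to compound 2 (0.74 log units; beyond the scatter), which was at least modest and went toward weaker binding. It does not show how a pentynyl chain compares, and compound 2 itself is only a limit, so the expected step of an at least 1.3-fold lower number from compound 2 to compound 3 (0.12 log units; that floor lies within the scatter) is uncertain. In this assay compound 3 is estimated at 1500 nM, between 300 nM and 6000 nM.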

Compound 3, half-maximal inhibitory concentration: > 2000 nM
Compound 3: no number, only a limit (the forecaster's own chance of this, stated with the estimate: 45%); at least 1.3-fold (0.12 log units) between middle value and limit.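

In this assay, compound 3 also returns only a limit, so a second open chain now sits at the weak end of what can be read: the limit of > 2000 nM in this assay, at which 2 of the 3 values shown sit.

The change from cyclohexyl to pent-2-yn-1-yl gives an at least 5.5-fold higher number from compound 1 to compound 3 (0.74 log units; beyond the scatter), so this chain, with its triple bond and no hydrogen-bond acceptor, also falls short of the cyclohexyl group at this position. Swapping isopropoxymethyl for but-1-yn-1-yl therefore brings no readable recovery, and the step between compound 2 and compound 3 cannot be read, as both values are limits.

Going by these compounds, how far compound 2 and compound 3 lie beyond the limit stays open, and so does any order between them. Also open, on these data alone, is whether a different ring on the same oxygen, such as cyclopentyl or phenyl, would match the cyclohexyl group of compound 1.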